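The compounds below may be only part of what the source reports. "The series", "measured", "known", "first", "only" and "open" are said of these compounds alone.

Of the compounds shown here, two have so far been measured in a functional assay on aorta for antagonist activity at Alpha-1D adrenergic receptor (Rattus norvegicus); on this read-out higher numbers stand for weaker binding and lower numbers for tighter binding. Compound 2 `CN(C)C(=O)c1cccnc1NCCCN1CCN(c2ccccc2C#N)CC1` gives 10 nM in this assay, and compound 1 `COc1ccccc1N1CCN(CCCNc2ccncc2C(=O)N(C)C)CC1` gives 50.1 nM. Of these two numbers compound 2 has the lower one, and its gap to compound 1 lies beyond the usual scatter; since compound 1 and compound 2 differ from each other in more than one place, that gap cannot be tied to any single change. Compound 3 `Cc1ccccc1N1CCN(CCCNc2ncccc2C(=O)N(C)C)CC1` has not yet been measured. It differs from compound 2 in one place only: methyl in place of cyano on an aromatic carbon. Going by the values given here, no measured pair shows this change by itself, so any expectation rests on little. A modest shift toward a higher number, not far beyond the scatter, is expected, meaning a step of a 2.5-fold higher number from compound 2 to compound 3 (0.40 log units; beyond the scatter). For compound 3 the estimate in this assay is 25 nM, with a range from 8 nM to 80 nM.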

Compound 3, dissociation constant: 10 nM
Estimate against measurement, compound 3: 2.5-fold (0.40 log units) above, within the range that was stated.
By their numbers in this assay, from the lowest: compounds 2 and 3 (each within the scatter of the next); then compound 1.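

Replacing cyano with methyl on an aromatic carbon, ortho to a large group, gives in this assay no change at the digits printed from compound 2 to compound 3 (within the scatter). Going by these compounds alone, this is the first single change that can be read, and it shows that this position accepts either group on this read-out, even though methyl has one heavy atom fewer, no triple bond and no hydrogen-bond acceptor. No available measurement bears on why the two groups give matching numbers.

On these data alone, it remains open whether an amine, a carboxylic acid or a chlorine atom on the same carbon would also leave the number in place. Compound 1 carries a methoxy group on its ring but differs from the other two compounds in more than one place, so it cannot settle this.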